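Iodo for Bromo on the Strongest Compound

This account rests on a few compounds, and the source may have more. Where it says the series, first, only, none or still open, it means among the compounds named here.

In a functional assay on HT-29 cells (Homo sapiens) for cytotoxicity, read by sulforhodamine B assay, with a stated time of 72 h (a lower number here means a stronger inhibitor, a higher number a weaker inhibitor), compound 2 (`CCCCC/C=C\C[C@@]1(O)C=C(Br)C(=O)/C1=C\C=C\CCCC(=O)OC`) gives 500 nM and so holds the lowest number of the three compounds measured, making it the strongest of them. Compound 3 (`CCCCC/C=C\C[C@@]1(O)C=C(Br)C(=O)/C1=C/C=C/CCCC(=O)OC`) gives 5400 nM on the same scale and compound 1 (`CCCCC/C=C\C[C@@]1(O)C=C(I)C(=O)/C1=C/C=C/CCCC(=O)OC`) gives 6500 nM there.

Compound 4 (`CCCCC/C=C\C[C@@]1(O)C=C(I)C(=O)/C1=C\C=C\CCCC(=O)OC`) has not been measured yet. It departs from compound 2 by a single change on the shared core: iodo in place of bromo on a double-bonded ring carbon. Its configuration matches that of compound 2.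

Two measured steps are worth weighing. The large one is an 11-fold higher number from compound 2 to compound 3 (1.03 log units; beyond the scatter) and it is due to the fact that compounds 2 and 3 differ only in the configuration as drawn alone, so it says little about a halogen exchange. Among the measured compounds shown here, the one measured swap between these two halogens gave a 1.2-fold lower number from compound 1 to compound 3 (0.08 log units; within the scatter) and on that basis no step beyond the scatter is expected in this assay for compound 4. That pair has the other configuration, so the support is indirect and the range stays wide.

The expected change is a 1.2-fold higher number from compound 2 to compound 4 (0.08 log units; within the scatter) and no larger. For compound 4 the estimate is 600 nM with an expected range from 280 nM to 1300 nM in this measurement.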

Compound 4, half-maximal inhibitory concentration: > 10000 nM
Compound 4: no number, only a limit; the forecaster's own chance of this, stated with the estimate: 2%; middle value at least 16-fold (1.22 log units) from the limit.
By their numbers in this assay, from the lowest: compound 2; then compounds 3 and 1 (each within the scatter of the next). At a limit, above all of these: compound 4.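

Compound 4 gives > 10000 nM in this assay, and that value is a limit of the assay, not a number. Measured against that limit, iodo in place of bromo on this double-bonded ring carbon is a large step on the core of compound 2, an at least 20-fold higher number from compound 2 to compound 4 (1.30 log units; beyond the scatter), so a swap that stayed within the scatter on the other configuration does not stay there on this one: the same change on two cores in this assay, a 1.2-fold lower number (0.08 log units; within the scatter) from compound 1 to compound 3 and an at least 20-fold lower number (1.30 log units; beyond the scatter) from compound 4 to compound 2, at least 16-fold (1.22 log units) apart, beyond the scatter of two such steps. With iodo at this position, changing the configuration of the double bond shows no gain, only an at least 1.5-fold higher number from compound 1 to compound 4 (0.18 log units; that floor lies within the scatter), while the matching change with bromo is large, an 11-fold higher number from compound 2 to compound 3 (1.03 log units; beyond the scatter).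

The compounds shown leave open how this ring carbon responds to other groups, such as chloro or a plain hydrogen, which could show whether bromo or iodo is the unusual case on the core of compound 2. They also leave open whether the gap between the two halogens persists when a carboxylic acid replaces the methyl ester at the end of the chain.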